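This account rests on a few compounds, and the source may have more. Where it says the series, first, only, none or still open, it means among the compounds named here.

Measured so far in a functional assay for activation of Alpha-1D adrenergic receptor (Homo sapiens); a lower number here means that less compound is needed, a higher number that more compound is needed for the effect:
Compound 1, `Cc1noc(-c2ccccc2NCC2=NCCN2)n1`, gives < 5020 nM, which is a limit of the assay and not a number.
Compound 2, `c1ccc(-c2ccccc2NCC2=NCCN2)nc1`, gives 41.7 nM.
Compound 3, `Cc1cccnc1-c1ccccc1NCC1=NCCN1`, gives < 100000 nM, again a limit rather than a measured number.

Compound 3 therefore stands only on a limit: its place among the three values is not fixed, and one of the other two values shown is a limit as well. Both the step that the limit leaves unreadable from compound 1 to compound 2 and the step that the limit leaves unreadable from compound 2 to compound 3 are unreadable for that reason, the first through the limit of < 5020 nM in this assay, at which 1 of the 3 values shown sits, and the second through (the limit of < 100000 nM in this assay, at which 1 of the 3 values shown sits), so no measured step gives a readable size for a change at this part of the shared core.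

The next compound is compound 4, `FC(F)(F)c1cccnc1-c1ccccc1NCC1=NCCN1`. The change from compound 3 is trifluoromethyl in place of methyl on an aromatic carbon. Among the compounds with values here, none of the measured steps bears on it in a readable way, and compound 2 is the only number available as an anchor. Compound 4 is expected to land at 500 nM, with a range from 30 nM to 10000 nM. The step that the limit leaves unreadable from compound 3 to compound 4 that this estimate implies is an expectation only, and a further limit rather than a number would not be surprising.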

Compound 4, half-maximal effective concentration: < 100000 nM
Compound 4: no number, only a limit (the forecaster's own chance of this, stated with the estimate: 30%); the middle value does not contradict the limit.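

In this assay compound 4 gives < 100000 nM, which is a limit and not a number. Neither the step from compound 3 to compound 4 nor the step from compound 2 to compound 4 can be read. The compounds shown leave open how much methyl or trifluoromethyl at this place changes the value; compound 2 remains the only one here with a measured number.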